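The source may hold more compounds than are shown below. What is called first, only, known or untested is meant among the compounds shown, and "the series" means these compounds.

Measured so far:

compound 1, `C=CC(=O)Nc1cccc(NC(=O)CSc2nc(Nc3ccccc3)c3ccccc3n2)c1`, gives 8120 nM
compound 2, `C=CC(=O)Nc1cccc(NC(=O)CSc2nc(Nc3ccccc3F)c3ccccc3n2)c1`, gives 6580 nM
compound 3, `C=CC(=O)Nc1cccc(NC(=O)CSc2nc(Nc3cccc([N+](=O)[O-])c3)c3ccccc3n2)c1`, gives 22600 nM

All three numbers come from a functional assay on NCI-H1975 cells (Homo sapiens) for inhibition, read by MTT assay, with a stated time of 72 h; on this read-out lower numbers stand for stronger inhibition and higher numbers for weaker inhibition. Compound 3 stands at the highest number of the three: the step of a 2.8-fold higher number from compound 1 to compound 3 (0.44 log units; beyond the scatter) and the step of a 3.4-fold higher number from compound 2 to compound 3 (0.54 log units; beyond the scatter) both go beyond the scatter, whereas a 1.2-fold lower number from compound 1 to compound 2 (0.09 log units; within the scatter) stays within it. Compound 4, `C=CC(=O)Nc1cccc(NC(=O)CSc2nc(Nc3cccc(OC)c3)c3ccccc3n2)c1`, differs from compound 3 in one place: methoxy in place of nitro on an aromatic carbon. Within the data shown here, no measured step exchanges these two groups for each other, so the only guide is indirect. The step of a 2.8-fold higher number from compound 1 to compound 3 (0.44 log units; beyond the scatter) shows that putting the nitro group onto this ring raised the number by a modest amount, and removing it would be expected to undo that. Whether the methoxy group taking its place adds or takes away anything cannot be read from the three values, so compound 4 is expected to land somewhere between compound 1 and compound 3, with wide uncertainty. The expected step is a 2.1-fold lower number from compound 3 to compound 4 (0.31 log units; beyond the scatter). Compound 4 is estimated at 11000 nM, within a range from 4500 nM to 30000 nM.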

Compound 4, half-maximal inhibitory concentration: 7940 nM
Estimate against measurement, compound 4: 1.4-fold (0.14 log units) above; low and high end bracket the measured number.
By their numbers in this assay, from the lowest: compounds 2, 4 and 1 (each within the scatter of the next); then compound 3.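

Putting methoxy in place of nitro gives a 2.8-fold lower number from compound 3 to compound 4 (0.45 log units; beyond the scatter) and so removes the rise seen with compound 3: a group on this ring carbon does not raise the number merely by being there. Adding methoxy to the plain phenyl ring gives a 1.0-fold lower number from compound 1 to compound 4 (0.01 log units; within the scatter) and changing the ring from 2-fluorophenyl to 3-methoxyphenyl gives a 1.2-fold higher number from compound 2 to compound 4 (0.08 log units; within the scatter) so neither comparison shows a real difference. Nothing measured here explains why nitro and methoxy part ways at this position.

On these data alone, whether an amine or a carboxylic acid on this ring carbon would stay level with compound 1 or shift the number as nitro does remains open. So does whether methoxy on another carbon of the ring would leave the number as unchanged as it does here.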